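The source may report more compounds than this note shows. Statements on the series, on what has been measured and on what is new or still open speak of the compounds shown alone.

For the measured compounds named here, in an ADME assay on the whole organism (plasma) for metabolic stability, with Canis familiaris (Canis lupus familiaris) as the target (a lower number here means that the compound disappears faster, a higher number that the compound lasts longer), compound 2 `NC1CCN(C(=O)c2ccc3[nH]c(-c4cc5ccccc5nc4O)cc3c2)C1` gives 1.1 h, the lower of the two numbers so far. Compound 1 `O=C(O)C1CCN(CCCOc2ccc3[nH]c(-c4cc5ccccc5nc4O)cc3c2)CC1` gives 3.2 h. The gap between these two compounds lies beyond the scatter. Compound 3 `O=C(NC1CCNC1)c1ccc2[nH]c(-c3cc4ccccc4nc3O)cc2c1` has the same atoms joined differently, with (pyrrolidin-3-yl)amino in place of 3-aminopyrrolidin-1-yl on a carbonyl carbon. Going by the values given here, no measured pair shows this change, so the expectation remains loose. The expected step of a 1.3-fold higher number from compound 2 to compound 3 (0.10 log units; within the scatter) stays within the scatter, leaning slightly towards a longer half-life. In this assay the estimate for compound 3 is 1.4 h, with an expected range of 0.7 h to 3.2 h.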

Compound 3, half-life: 1.7 h
Beside the measured number, compound 3's estimate is 1.2-fold (0.08 log units) below it; low and high end bracket the measured number.
By their numbers in this assay, from the lowest: compounds 2, 3 and 1 (each within the scatter of the next, the first and the last beyond it).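

The step of a 1.5-fold higher number from compound 2 to compound 3 (0.19 log units; within the scatter) in this assay comes from (pyrrolidin-3-yl)amino in place of 3-aminopyrrolidin-1-yl on a carbonyl carbon. The two arrangements of the same atoms are therefore not told apart at this position, a reading that compound 1 and compound 2, which differ in more than one place, could not give. No measurement at hand accounts for this result.

Going by these compounds, whether a piperidin-4-ylamino group or a carboxylic acid on a longer chain at this carbonyl carbon would give a step beyond the scatter remains open.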